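Aryl sulfonamide series: a 3,5-dimethylphenyl variant of compound 1

The compounds below may be only part of what the source reports. "The series", "measured", "known", "first", "only" and "open" are said of these compounds alone.

Compound 1 `CCc1ccccc1NS(=O)(=O)c1ccc(N2CCNC2=O)cc1` is the reference point. Among the compounds with values here, in a functional assay on MCF7 cells (Homo sapiens) for antiproliferative activity, read by sulforhodamine B assay, with a stated time of 48 h (a higher number here means a weaker inhibitor, a lower number a stronger inhibitor), compound 1 gives 350 nM, the highest of the two numbers measured so far; its nearest neighbour is compound 2 `Cc1ccc(NS(=O)(=O)c2ccc(N3CCNC3=O)cc2)cc1C`, which in this assay gives 230 nM. Within the data shown here, the step of a 1.5-fold lower number from compound 1 to compound 2 (0.18 log units; within the scatter) is the only measured comparison, and it exchanges one alkyl-substituted phenyl for another on the sulfonamide nitrogen. Compound 3 `Cc1cc(C)cc(NS(=O)(=O)c2ccc(N3CCNC3=O)cc2)c1` is the next variant. Relative to compound 1 the change is 3,5-dimethylphenyl in place of 2-ethylphenyl on a sulfonamide nitrogen. Among the measured compounds shown here, the one comparable step, a 1.5-fold lower number from compound 1 to compound 2 (0.18 log units; within the scatter), stayed within the scatter, so no larger movement is expected from a second exchange of the same kind: a step of about a 1.2-fold lower number from compound 1 to compound 3 (0.08 log units; within the scatter) is expected, that is nothing beyond the scatter in either direction. Compound 3 is therefore estimated at 290 nM in this assay, with a range from 140 nM to 600 nM.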

Compound 3, half-maximal inhibitory concentration: 100 nM
Estimate against measurement, compound 3: 2.9-fold (0.46 log units) above, and the stated range ends above it.
By their numbers in this assay, from the lowest: compound 3; then compounds 2 and 1 (each within the scatter of the next).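

On the sulfonamide nitrogen, exchanging one alkyl-substituted phenyl for another can move the number in this assay beyond the scatter: 3,5-dimethylphenyl in place of 2-ethylphenyl gives (a 3.5-fold lower number from compound 1 to compound 3 (0.54 log units; beyond the scatter)). The two dimethylphenyl isomers also separate (a 2.3-fold lower number from compound 2 to compound 3 (0.36 log units; beyond the scatter)), so at this position the arrangement of the two methyl groups on the phenyl ring makes a modest difference, and compound 3 has the lowest number of the three, with both its steps beyond the scatter. Nothing at hand offers an explanation for this difference.

As far as these compounds go, whether one methyl group alone would give the same number remains open. So does whether the result for 3,5-dimethylphenyl holds up when the methyl groups are replaced by methoxy, chlorine or a carboxylic acid.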